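Swapping Methoxy for Bromo on the Benzyl Ring

A few compounds are considered here, and "the series" means these few. Any claim that something is new, unique, unknown or untested is made for them only; others in the source may bear on it.

Compound 1 `COc1ccc(CN2CCC(CCNC(=O)/C=C/c3cc(C(C)(C)C)c(O)c(C(C)(C)C)c3)CC2)cc1` carries a methoxy group on the benzyl ring at one end of the shared core. In a functional assay, read by spectrophotometry, with a stated time of 30 min (on this read-out higher numbers stand for weaker inhibition and lower numbers for stronger inhibition), compound 1 gives 61200 nM. Going by the values given here, two companions alter only that ring. Compound 2 `CC(C)(C)c1cc(/C=C/C(=O)NCCC2CCN(Cc3ccccc3F)CC2)cc(C(C)(C)C)c1O` gives 55900 nM, and compound 3 `CC(C)(C)c1cc(/C=C/C(=O)NCCC2CCN(Cc3ccc(F)cc3F)CC2)cc(C(C)(C)C)c1O` gives 62400 nM. Among these three numbers compound 1 stands second highest, and every pair lies within the scatter: a 1.1-fold lower number from compound 1 to compound 2 (0.04 log units; within the scatter), a 1.0-fold higher number from compound 1 to compound 3 (0.01 log units; within the scatter), and a 1.1-fold higher number from compound 2 to compound 3 (0.05 log units; within the scatter). So far, then, changing what sits on this ring has left the read-out where it was.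

Compound 4 `CC(C)(C)c1cc(/C=C/C(=O)NCCC2CCN(Cc3ccc(Br)cc3)CC2)cc(C(C)(C)C)c1O` is the next step from compound 1: bromo in place of methoxy on an aromatic carbon. Among the compounds with values here, no measured pair tests bromo directly, but the three steps above all touch this same ring, and none of them went beyond the scatter, so the same outcome is expected here: no step beyond the scatter in this assay, in either direction. On that basis compound 4 is estimated at 60000 nM, with a likely range from 30000 nM to 120000 nM, which means an expected step of a 1.0-fold lower number from compound 1 to compound 4 (0.01 log units; within the scatter).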

Compound 4, half-maximal inhibitory concentration: 85600 nM
For compound 4 the middle estimate is 1.4-fold (0.15 log units) below the measured one, within the range that was stated.
By their numbers in this assay, from the lowest: compounds 2, 1, 3 and 4 (each within the scatter of the next).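

Bromo at this place, para to a large group, is a different kind of test from the fluoro compounds: a single heavy atom replaces the two of methoxy, and the one hydrogen-bond acceptor counted for methoxy goes with it, yet the result is a 1.4-fold higher number from compound 1 to compound 4 (0.15 log units; within the scatter). Measured against the two fluorinated rings, the 4-bromobenzyl compound gives a 1.4-fold higher number from compound 3 to compound 4 (0.14 log units; within the scatter) and a 1.5-fold higher number from compound 2 to compound 4 (0.19 log units; within the scatter), so in this assay no step among these four compounds goes beyond the scatter, even where the ring differs in more than one atom. Nothing measured alongside these numbers offers an explanation for them.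

The compounds shown carry only methoxy, fluoro or bromo on this ring, so it remains open whether a group of another type there, such as an amine or a carboxylic acid, would give a step beyond the scatter. Also untested is whether a longer chain between the ring and the amine nitrogen would do so, since every compound here keeps the same single carbon link.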